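Halogen Swap on the Benzyl Group of a Sulfonamide Series

The source may report more compounds than this note shows. Statements on the series, on what has been measured and on what is new or still open speak of the compounds shown alone.

Measured compounds:
compound 1 `O=S(=O)(NCCCNCc1ccc(Cl)c(Cl)c1)c1cc(C(F)(F)F)cc(C(F)(F)F)c1` gives 2800 nM in a functional assay on ASPC1 cells (Homo sapiens) for inhibition, read by MTT assay, with a stated time of 72 h; a lower number here means a stronger inhibitor of growth, a higher number a weaker inhibitor of growth
compound 2 `O=S(=O)(NCCCNCC1COc2ccccc2O1)c1cc(C(F)(F)F)cc(C(F)(F)F)c1` gives 2900 nM
compound 3 `O=S(=O)(NCCCNCc1ccc(Br)cc1)c1cc(C(F)(F)F)cc(C(F)(F)F)c1` gives 2800 nM

In this assay compound 3 sits level with compound 1, the two together giving the lowest numbers of the three; the gap a 1.0-fold lower number from compound 2 to compound 3 (0.02 log units; within the scatter) is within the scatter, as is no change at the digits printed from compound 1 to compound 3 (within the scatter). Compound 4 `O=S(=O)(NCCCNCc1cccc(Cl)c1)c1cc(C(F)(F)F)cc(C(F)(F)F)c1` differs from compound 3 by 3-chlorophenyl in place of 4-bromophenyl on a saturated chain carbon bound to an amine nitrogen. Among the measured compounds shown here, the steps that bear on it, no change at the digits printed from compound 1 to compound 3 (within the scatter) and a 1.0-fold higher number from compound 1 to compound 2 (0.02 log units; within the scatter), show that exchanging the group on this chain carbon moved nothing beyond the scatter. Compound 4 is therefore expected to give 2800 nM, within 1400 nM to 5600 nM, a step of no change at the digits printed from compound 3 to compound 4 (within the scatter) that is estimated to stay within the scatter.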

Compound 4, concentration for 50% growth inhibition: 5900 nM
Compound 4: the middle estimate sits 2.1-fold (0.32 log units) below what was measured, and the stated range ends below it.
By their numbers in this assay, from the lowest: compounds 1, 3 and 2 (each within the scatter of the next); then compound 4.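

In this assay, among the compounds shown here, this is the first exchange on this chain carbon to move beyond the scatter, with a 2.1-fold higher number from compound 3 to compound 4 (0.32 log units; beyond the scatter) and a 2.0-fold higher number from compound 2 to compound 4 (0.31 log units; beyond the scatter), both modest. Hydrogen in place of chloro on an aromatic carbon also matters here, giving a 2.1-fold higher number from compound 1 to compound 4 (0.32 log units; beyond the scatter), so the 3-chlorophenyl group yields a weaker inhibitor of growth than the 3,4-dichlorophenyl group. No evidence is available to explain these steps.

Still open, as far as these compounds go, is whether the step from compound 3 follows the identity of the halogen or where it sits on the ring. A 4-chlorophenyl or a 3-bromophenyl group on this chain carbon would separate the two.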